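The source may report more compounds than this note shows. Statements on the series, on what has been measured and on what is new or still open speak of the compounds shown alone.

Measured compounds in this set:

compound 1, `NC(=S)Nc1cccc(OCCCCCCCCNC(=S)Nc2ccc(Br)cc2)c1`: 18000 nM
compound 2, `NC(=S)Nc1cccc(OCCCCCCCCNC(=S)Nc2ccc(Cl)cc2)c1`: 18000 nM

In an ADME assay on Huh-7 cells (Homo sapiens) for cytotoxicity (a lower number here means that less compound is tolerated, a higher number that more compound is tolerated), compound 1 gives 18000 nM and compound 2 gives 18000 nM. For the measured compounds named here, the single one-point step available, no change at the digits printed from compound 1 to compound 2 (within the scatter), exchanges one halogen for another on the aromatic ring of the shared core. On the numbers, compound 2 stands level with compound 1 at the digits reported; the two values lie within the scatter of each other, so no ordering between them can be drawn.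

Compound 3, `NC(=S)Nc1cccc(OCCCCCCCCNC(=S)Nc2ccc(C3CCCCC3)cc2)c1`, is not yet measured. Against compound 2 the change is cyclohexyl in place of chloro on an aromatic carbon. Going by the values given here, the only measured step bears on it weakly: no change at the digits printed from compound 1 to compound 2 (within the scatter) shows that swapping the halogen leaves the tolerated concentration unchanged, but it says nothing about the entry of a cyclohexyl at the same aromatic carbon. Among the compounds with values here, with no measured step covering a ring entering at this site, no direction beyond the scatter can be claimed, and the range must be kept broad.

For compound 3 the expected value in this assay is 12000 nM, with a range from 4000 nM to 30000 nM. The step this estimate implies, a 1.5-fold lower number from compound 2 to compound 3 (0.18 log units; within the scatter), is expected to stay within the scatter, with the lower end of the range allowing for less compound being tolerated.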

Compound 3, half-maximal cytotoxic concentration: > 50000 nM
Compound 3: a limit, no number (the forecaster's own chance of this, stated with the estimate: 15%); middle value at least 4.1-fold (0.61 log units) away from the limit.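

In this assay this aromatic carbon proves responsive to the group it carries: cyclohexyl in place of chloro gives an at least 2.7-fold higher number from compound 2 to compound 3 (0.44 log units; beyond the scatter), and cyclohexyl in place of bromo gives an at least 2.7-fold higher number from compound 1 to compound 3 (0.44 log units; beyond the scatter). The halogen exchange alone, no change at the digits printed from compound 1 to compound 2 (within the scatter), showed no such separation, so the level shared by compound 1 and compound 2 does not hold for every group at this site, and more compound is tolerated with the cyclohexyl in place. Compound 3 gives a limit, not a number, so both steps fix only a smallest size: the limit of > 50000 nM in this assay, at which 1 of the 3 values shown sits.

From the compounds shown here alone, what stays open is whether the higher number goes with the ring itself or simply with the larger count of carbon atoms, a distinction that a hexyl chain or a phenyl at the same aromatic carbon would address. Also open, going by these compounds, is whether the tolerated concentration stays high with a group of a different kind at this carbon, such as an amine or a carboxylic acid, and how far the true value of compound 3 lies from the limit.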